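Benzyl for Pyridinyl on the Piperazine Nitrogen of Compound 1

The compounds below may be only part of what the source reports. "The series", "measured", "known", "first", "only" and "open" are said of these compounds alone.

Compound 1 `COc1ccc(NC(=O)Nc2nc(Sc3c[nH]c4ccccc34)cc(N3CCN(c4ccccn4)CC3)n2)cc1` gives the lowest of the three numbers in a functional assay on HepG2 cells (Homo sapiens) for inhibition, with a stated time of 72 h (on this read-out higher numbers stand for weaker inhibition and lower numbers for stronger inhibition), namely 11400 nM. Compound 2 `COc1ccc(NC(=O)Nc2nc(Nc3cc(OC)cc(OC)c3)cc(Sc3c[nH]c4ccccc34)n2)cc1` gives 17400 nM and compound 3 `COc1ccc(NC(=O)Nc2nc(Sc3c[nH]c4ccccc34)cc(N3CCCC3)n2)cc1` gives 20300 nM. The step of a 1.5-fold higher number from compound 1 to compound 2 (0.18 log units; within the scatter) and the step of a 1.8-fold higher number from compound 1 to compound 3 (0.25 log units; within the scatter) lie within the scatter, as does a 1.2-fold higher number from compound 2 to compound 3 (0.07 log units; within the scatter). Compound 4 `COc1ccc(NC(=O)Nc2nc(Sc3c[nH]c4ccccc34)cc(N3CCN(Cc4ccccc4)CC3)n2)cc1` differs from compound 1 by benzyl in place of pyridin-2-yl on an amine nitrogen in a ring. Within the data shown here, no measured step touches this ring nitrogen; all three measured steps exchange the group on the aromatic carbon, and none moves the number beyond the scatter, so the new change has no direct precedent here. The step of a 1.1-fold higher number from compound 1 to compound 4 (0.02 log units; within the scatter) is therefore estimated to stay within the scatter. Compound 4 is expected to give about 12000 nM in this assay, within a range of 5000 nM to 30000 nM.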

Compound 4, half-maximal inhibitory concentration: 21400 nM
Estimate against measurement, compound 4: 1.8-fold (0.25 log units) below; measured number inside the range.
By their numbers in this assay, from the lowest: compounds 1, 2, 3 and 4 (each within the scatter of the next).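

In this assay, benzyl in place of pyridin-2-yl on an amine nitrogen in a ring gives a 1.9-fold higher number from compound 1 to compound 4 (0.27 log units; within the scatter), the first step read at this nitrogen. Exchanging a ring with one hetero atom for a ring of carbon only, with one hydrogen-bond acceptor fewer, therefore stays within the scatter here, as the exchanges on the aromatic carbon did. Nothing available explains this result. On these data alone, whether a methyl, an acetyl or a bare hydrogen on this nitrogen, or a carboxylic acid on the benzyl ring, would give a step beyond the scatter remains open.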